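This account rests on a few compounds, and the source may have more. Where it says the series, first, only, none or still open, it means among the compounds named here.

Series notes. Compound 1 `O=c1c(CSC(=S)N2CCN(c3ccccc3)CC2)coc2ccccc12`, compound 2 `O=c1cc(CSC(=S)N2CCCCC2)oc2ccccc12` and compound 3 `O=c1c(Cl)c(CSC(=S)N2CCCCC2)oc2ccccc12` share the core of compound 1, each carrying a thiocarbonyl-linked side chain. In a functional assay on LM7 cells (Homo sapiens) for antiproliferative activity, read by MTT assay, with a stated time of 72 h (a lower number here means a stronger inhibitor, a higher number a weaker inhibitor), compound 1 gives 2900 nM. For compound 2 this assay reports only a limit, > 25000 nM, which sits at the limit of > 25000 nM in this assay, at which 1 of the 3 values shown sits. Compound 3 gives 3300 nM in this assay, the highest of the two numbers shown, though its gap to compound 1 lies within the scatter. Among the measured compounds shown here, the one measured step, an at least 7.5-fold lower number from compound 2 to compound 3 (0.87 log units; beyond the scatter), concerns the chloro group and not the amine part of the side chain. Compound 4 `CC(C)N(C(=S)SCc1oc2ccccc2c(=O)c1Cl)C(C)C` differs from compound 3 by diisopropylamino in place of piperidin-1-yl on a thiocarbonyl carbon. For the measured compounds named here, no measured step touches that part of the molecule, so the chloro step gives no direct guide, and the exchange of one small saturated amine for another is expected to leave this assay unmoved beyond the scatter. Compound 4 is therefore expected to give about 3300 nM in this assay, within 1500 nM to 8000 nM, a step of no change at the digits printed from compound 3 to compound 4 (within the scatter).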

Compound 4, half-maximal inhibitory concentration: > 40000 nM
Compound 4 ended at the assay's limit (the forecaster's own chance of this, stated with the estimate: 10%); middle value at least 12-fold (1.08 log units) from the limit.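

With the chloro group held constant, diisopropylamino in place of piperidin-1-yl on a thiocarbonyl carbon gives an at least 12-fold higher number from compound 3 to compound 4 (1.08 log units; beyond the scatter) in this assay, so the amine part of the side chain is a place where this read-out responds. The chloro group alone therefore does not secure a measurable value; compound 4 keeps that group and reports only a limit, not a number: the limit of > 40000 nM in this assay, at which 1 of the 4 values shown sits.

Among the compounds shown here, the change replaces a six-membered non-aromatic ring with an amine that has no ring, and the sole comparison available ties the loss to that exchange as a whole. As far as these compounds go, whether the ring itself decides the outcome stays open; diethylamino or pyrrolidin-1-yl on the same thiocarbonyl carbon would bear on this. Also open, from the compounds shown here alone, is whether the amine exchange reads the same without the chloro group.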